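Trimming the Amide Substituent from Cyclopentyl to Methyl

The compounds below may be only part of what the source reports. "The series", "measured", "known", "first", "only" and "open" are said of these compounds alone.

Of the compounds shown here, three built on one shared core have so far been tested in a functional assay on MCF7 cells (Homo sapiens) for antiproliferative activity, read by CCK-8 assay, with a stated time of 72 h; a higher number here means a weaker inhibitor of growth, a lower number a stronger inhibitor of growth. Compound 1 `CC[C@@H]1C(=O)N(C)c2cnc(Nc3ccc(S(=O)(=O)NCCO)cc3)nc2N1C1CCCC1` gives 344 nM. Compound 2 `CC[C@@H]1C(=O)N(C)c2cnc(-n3ccc4cc(C(=O)NCC(C)C)ccc43)nc2N1C1CCCC1` gives 953 nM, and compound 3 `CC[C@@H]1C(=O)N(C)c2cnc(-n3ccc4cc(C(=O)NC5CCCC5)ccc43)nc2N1C1CCCC1` gives 795 nM, the second highest number of the three, separated from compound 1 by a gap beyond the scatter and from compound 2 by one within it. Compound 4 `CC[C@@H]1C(=O)N(C)c2cnc(-n3ccc4cc(C(=O)NC)ccc43)nc2N1C1CCCC1` differs from compound 3 by methyl in place of cyclopentyl on an amide-type nitrogen. Among the measured compounds shown here, only one measured step bears on this change: a 1.2-fold lower number from compound 2 to compound 3 (0.08 log units; within the scatter), which stayed within the scatter, so the expected step of a 1.3-fold higher number from compound 3 to compound 4 (0.10 log units; within the scatter) is small as well, with no clear direction. Compound 4 is therefore estimated at 1000 nM, within a range from 450 nM to 2200 nM.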

Compound 4, concentration for 50% growth inhibition: 1000 nM
Estimate against measurement, compound 4: no gap at the digits printed; low and high end bracket the measured number.
By their numbers in this assay, from the lowest: compound 1; then compounds 3, 2 and 4 (each within the scatter of the next).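

In this assay, cutting the amide substituent from cyclopentyl, with 5 heavy atoms and a ring, to methyl, with 1 heavy atom and no ring, gives a 1.3-fold higher number from compound 3 to compound 4 (0.10 log units; within the scatter), and the change from isobutyl to methyl gives a 1.0-fold higher number from compound 2 to compound 4 (0.02 log units; within the scatter). With methyl added, three substituents on this amide-type nitrogen now sit within the scatter of one another, so even the smallest of them leaves the number in place. No evidence given here explains this flat result. Still open, as far as these compounds go, is whether an amine or a carboxylic acid on this nitrogen would move the number beyond the scatter.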